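A few compounds are considered here, and "the series" means these few. Any claim that something is new, unique, unknown or untested is made for them only; others in the source may bear on it.

Of the compounds shown here, three of related build have been tested in a functional assay on HL-60 cells (Homo sapiens) for cytotoxicity, read by MTT assay, with a stated time of 4 days (a lower number here means a stronger inhibitor, a higher number a weaker inhibitor), and a fourth awaits its result.

Compound 3 `COc1ccc(-c2cn(C[C@H]3c4c(ccc(OS(=O)(=O)c5ccc(C)cc5)c4C)[C@@H]4CC[C@@]5(C)C[C@]43CC5=O)nn2)cc1` carries a 4-methoxyphenyl group on its triazole. In this assay compound 3 gives > 20000 nM, which is a limit of the assay rather than a number. Compound 1 `Cc1ccc(S(=O)(=O)Oc2ccc3c(c2C)[C@H](Cn2cc(-c4ccc(Cl)cc4)nn2)[C@@]24CC(=O)[C@@](C)(CC[C@@H]32)C4)cc1` differs from it by chloro in place of methoxy on an aromatic carbon. In this assay compound 1 gives > 20000 nM, again a limit and not a number. The step that the two limits leave unreadable from compound 3 to compound 1 therefore cannot be sized, because both ends rest on (the limit of > 20000 nM in this assay, at which 3 of the 3 values shown sit).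

Compound 2 `C=C1C[C@]23C[C@@]1(O)CC[C@@H]2c1cccc(C)c1[C@@H]3Cn1cc(-c2ccc(OC)cc2)nn1` keeps the same 4-methoxyphenyl-triazole arm but sits on a different core; the difference between the two cores is not broken down here. In this assay compound 2 gives > 20000 nM, which is a limit.

Among the compounds with values here, compound 4 `C=C1C[C@]23C[C@@]1(O)CC[C@@H]2c1cccc(C)c1[C@@H]3Cn1cc(-c2ccc(Cl)cc2)nn1` is the not yet measured partner of compound 2 and differs from it by chloro in place of methoxy on an aromatic carbon; this is the same change as the one from compound 3 to compound 1, at the same place. Since that earlier change left both partners at the limit, and compound 2 itself sits at the limit with > 20000 nM, the step from compound 2 to compound 4 is expected to be a step that the limit leaves unreadable from compound 2 to compound 4, meaning no readable change. Compound 4 is accordingly expected to give about 30000 nM, with a plausible range from 8000 nM to 100000 nM, and most likely only a limit will be reported.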

Compound 4, half-maximal inhibitory concentration: > 20000 nM
Compound 4: only a limit was reported; the forecaster's own chance of this, stated with the estimate: 80%; the middle value does not contradict the limit.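

Compound 2 and compound 4 both end at a limit of the assay rather than a number, so the change from 4-methoxyphenyl to 4-chlorophenyl between them cannot be sized: the limit of > 20000 nM in this assay, at which 4 of the 4 values shown sit.

The compounds shown leave open whether chloro and methoxy differ at all in this assay, and what on either core would bring a value within the measurable range.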